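The source may hold more compounds than are shown below. What is called first, only, known or untested is meant among the compounds shown, and "the series" means these compounds.

Compound 1 `CCNC(=O)NOCc1ccc(/C=C/C(=O)NO)cc1` gives 14000 nM
Compound 2 `O=C(/C=C/c1ccc(CONC(=O)Nc2ccccc2)cc1)NO` gives 62000 nM
Compound 3 `O=C(/C=C/c1ccc(CONC(=O)c2ccccc2)cc1)NO` gives 2990 nM

Compound 3 (2990 nM) has the lowest number of the three in a functional assay on CAL-27 cells (Homo sapiens) for antiproliferative activity, read by MTT assay, with a stated time of 72 h (on this read-out higher numbers stand for weaker inhibition and lower numbers for stronger inhibition), and serves as the reference here. Compound 4 `Cc1cc(C)cc(C(=O)NOCc2ccc(/C=C/C(=O)NO)cc2)c1` carries 3,5-dimethylphenyl in place of phenyl on a carbonyl carbon. Two measured steps change the group on that carbonyl carbon, one large (a 21-fold lower number from compound 2 to compound 3 (1.32 log units; beyond the scatter)) and one modest (a 4.7-fold lower number from compound 1 to compound 3 (0.67 log units; beyond the scatter)). Neither adds anything to a phenyl, so they give no direction for this change. No step beyond the scatter is expected, although a modest step either way remains possible. The estimate means an expected small change (a 1.2-fold lower number from compound 3 to compound 4 (0.08 log units; within the scatter)). Compound 4 is estimated at 2500 nM (range 800 nM to 8000 nM).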

Compound 4, half-maximal inhibitory concentration: 2240 nM
Compound 4: the middle estimate sits 1.1-fold (0.05 log units) above what was measured; the range from low to high includes it.
By their numbers in this assay, from the lowest: compounds 4 and 3 (each within the scatter of the next); then compound 1; then compound 2.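

On the carbonyl carbon, 3,5-dimethylphenyl in place of phenyl stays within the scatter in this assay, with a 1.3-fold lower number from compound 3 to compound 4 (0.13 log units; within the scatter), so this phenyl accepts the two methyl groups with no separation from the unsubstituted ring. The separation from the groups bearing nitrogen on that carbonyl carbon also holds with the new ring: a 28-fold lower number from compound 2 to compound 4 (1.44 log units; beyond the scatter) against anilino, and a 6.3-fold lower number from compound 1 to compound 4 (0.80 log units; beyond the scatter) against ethylamino. No supporting data bear on these results. Still open, on these data alone, is how a single methyl, a methoxy, a carboxylic acid or an amine on this phenyl would read, and whether a cyclohexyl ring could replace it.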